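A few compounds are considered here, and "the series" means these few. Any claim that something is new, unique, unknown or untested is made for them only; others in the source may bear on it.

Measured so far in a functional assay on the whole organism for agonist activity, with Mus musculus as the target; on this read-out lower numbers stand for an effect already at smaller amounts and higher numbers for an effect only at larger amounts of compound:
compound 1 `CC(=O)N(C)C(C)C#CCn1ccnc1` gives 2 mg/kg;
compound 2 `CC(=O)N(C)C(C)C#CCn1ccnc1C` gives > 100 mg/kg, a limit of this assay and not a number;
compound 3 `CC(C#CCn1ccnc1)N1CCCC1=O` gives > 100 mg/kg, likewise a limit of this assay.

Among the measured compounds shown here, the one counted step is methyl in place of hydrogen on an aromatic carbon: an at least 50-fold higher number from compound 1 to compound 2 (1.69 log units; beyond the scatter). Both compound 2 and compound 3 sit at the limit of > 100 mg/kg in this assay, at which 2 of the 3 values shown sit. How the core of compound 3 differs from the core of compound 1 is not broken down here.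

Compound 4 `Cc1cncn1CC#CC(C)N1CCCC1=O` is not yet measured. It relates to compound 3 by methyl in place of hydrogen on an aromatic carbon. For the measured compounds named here, this is the same kind of change as the one from compound 1 to compound 2, not the same one: there the methyl enters between two ring nitrogen atoms, here next to the ring nitrogen, two ring bonds from the ring nitrogen. Since compound 3 is already only a limit, the step that the limit leaves unreadable from compound 3 to compound 4 is expected to be small and cannot be resolved against the earlier one. Compound 4 is expected to give about 300 mg/kg, most likely again reported as a limit, between 100 mg/kg and 3000 mg/kg.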

Compound 4, dose for half-maximal effect: > 100 mg/kg
Compound 4: no number, only a limit; the forecaster's own chance of this, stated with the estimate: 85%; the middle value lies beyond the limit too.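

Compound 3 and compound 4 are both only limits, so no step between them can be read in this assay: the limit of > 100 mg/kg in this assay, at which 3 of the 4 values shown sit.

The compounds shown leave open whether methyl in place of hydrogen on an aromatic carbon changes anything on the core of compound 3, and where either compound lies beyond that limit.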